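Ethoxy to propoxy on the shared core: cytotoxicity notes

The source may hold more compounds than are shown below. What is called first, only, known or untested is meant among the compounds shown, and "the series" means these compounds.

The series shares one core and varies the group on the aromatic carbon. Compound 1 `Nc1nc(OCC(F)(F)F)c2ncn(/C=C3/CC3(CO)CO)c2n1` carries a 2,2,2-trifluoroethoxy group; in an ADME assay on BCBL1 cells (Homo sapiens) for cytotoxicity, with a stated time of 7 days (on this read-out lower numbers stand for higher toxicity in this test and higher numbers for lower toxicity in this test), compound 1 gives only the limit > 20000 nM, not a number. Compound 2 `CCOc1nc(N)nc2c1ncn2/C=C1/CC1(CO)CO` carries ethoxy; in this assay compound 2 likewise gives only the limit > 20000 nM. Compound 3 `CCCCCCCCSc1nc(N)nc2c1ncn2/C=C1/CC1(CO)CO` carries octylsulfanyl; in this assay compound 3 also stops at the limit > 20000 nM. Accordingly the steps are unreadable: a step that the two limits leave unreadable from compound 1 to compound 2, a step that the two limits leave unreadable from compound 1 to compound 3 and a step that the two limits leave unreadable from compound 2 to compound 3. Compound 2 thus stands at the limit of > 20000 nM in this assay, at which 3 of the 3 values shown sit, together with every other value shown.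

Compound 4 `CCCOc1nc(N)nc2c1ncn2/C=C1/CC1(CO)CO` differs from compound 2 by methyl in place of hydrogen on a saturated chain carbon, two bonds along the chain from an oxygen on an aromatic ring. Among the compounds with values here, the steps that bear on this change are the ones from compound 2, a step that the two limits leave unreadable from compound 2 to compound 3 and a step that the two limits leave unreadable from compound 1 to compound 2; both are unreadable, and neither a larger chain nor a different chain end has moved a value off the limit. No step beyond the scatter is therefore expected for compound 4 in this assay, and the estimated step is a step that the limit leaves unreadable from compound 2 to compound 4. Compound 4 is expected to give 30000 nM in this assay, within 20000 nM to 60000 nM, most likely reported again only as a limit.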

Compound 4, half-maximal cytotoxic concentration: > 20000 nM
Compound 4: a limit, no number; the forecaster's own chance of this, stated with the estimate: 85%; the middle value is on the limit's open side.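

Compound 4 also stops at a limit, so no new step can be read from it to compound 1, compound 2 or compound 3; all four compounds sit at the same limit: the limit of > 20000 nM in this assay, at which 4 of the 4 values shown sit. The compounds shown leave open whether any group on the aromatic carbon of the shared core gives an actual number in this assay.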